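A few compounds are considered here, and "the series" means these few. Any claim that something is new, unique, unknown or untested is made for them only; others in the source may bear on it.

Three members of one series have been tested in an assay for inhibition of zeta-carotene desaturase, chloroplastic/chromoplastic (Capsicum annuum), using a Dixon plot, with a stated time of 8 h; a higher number here means a weaker inhibitor, a lower number a stronger inhibitor. Compound 1 `CCC(COc1ccccc1)OC(=O)NCc1ccccc1` is the parent; in this assay compound 1 reaches only the limit, > 100000 nM. Compound 2 `CCC(COc1ccccc1Cl)OC(=O)NCc1ccccc1` differs from it by chloro in place of hydrogen on an aromatic carbon, and in this assay compound 2 likewise gives no number but a limit, > 100000 nM. Compound 3 `CCC(COc1cccc(OC)c1)OC(=O)NCc1ccccc1` has methoxy in place of hydrogen on an aromatic carbon, and in this assay compound 3 also stops at a limit, > 100000 nM. The steps between them are therefore not readable: a step that the two limits leave unreadable from compound 1 to compound 2, a step that the two limits leave unreadable from compound 1 to compound 3 and a step that the two limits leave unreadable from compound 2 to compound 3. All that can be said is the limit of > 100000 nM in this assay, at which 3 of the 3 values shown sit.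

The next compound, compound 4 `CCC(COc1ccc(Cl)c(Cl)c1)OC(=O)NCc1ccccc1`, is reached from compound 2 by 3,4-dichlorophenyl in place of 2-chlorophenyl on an oxygen on a saturated carbon. Going by the values given here, none of the measured steps has a readable size, so there is no basis for expecting a step beyond the scatter in either direction; because of the limit of > 100000 nM in this assay, at which 3 of the 3 values shown sit, the most likely outcome is that compound 4 again returns only a limit. The account therefore expects the step from compound 2 to compound 4 to be a step that the limit leaves unreadable from compound 2 to compound 4. Compound 4 is estimated at 150000 nM, within a range from 30000 nM to 1000000 nM.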

Compound 4, half-maximal inhibitory concentration: > 100000 nM
Compound 4 was reported as a limit (the forecaster's own chance of this, stated with the estimate: 85%); the middle value is on the limit's open side.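

In this assay compound 4 also gives only a limit (> 100000 nM). Going by these compounds alone, no step between compound 4 and compound 1, compound 2 or compound 3 can be read. The compounds shown leave open whether phenyl, 2-chlorophenyl, 3-methoxyphenyl and 3,4-dichlorophenyl differ at all in this measurement, as all that stands is: the limit of > 100000 nM in this assay, at which 4 of the 4 values shown sit.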